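This account rests on a few compounds, and the source may have more. Where it says the series, first, only, none or still open, it means among the compounds named here.

Measured compounds:
Compound 1 `Cc1ccc(Cc2nc3cc(O[C@H]4CC[C@@H](C(=O)O)CC4)ccc3n2C)cc1` — in an assay on isolated protein for inhibition of Long-chain-fatty-acid--CoA ligase 1 (Homo sapiens), read by mass spectrometry, with a stated time of 90 min, in the presence of a further agent that is not named here (on this read-out lower numbers stand for stronger inhibition and higher numbers for weaker inhibition), compound 1 gives 150 nM.
Compound 2 `Cn1c(Cc2ccc3c(c2)OCC3)nc2cc(O[C@H]3CC[C@@H](C(=O)O)CC3)ccc21` — in this assay compound 2 gives 13 nM.
Compound 3 `Cc1cccc(C(=O)c2nc3cc(O[C@H]4CC[C@@H](C(=O)O)CC4)ccc3n2C)c1` — in this assay compound 3 returns only a limit, > 200000 nM, and no number.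

Compound 3 thus sits at the upper limit of this assay (the limit of > 200000 nM in this assay, at which 1 of the 3 values shown sits), the one of the three measured compounds for which no number could be read. The step to compound 4 `Cc1cccc(COc2nc3cc(O[C@H]4CC[C@@H](C(=O)O)CC4)ccc3n2C)c1` exchanges its linker: (3-methylbenzyl)oxy in place of (3-methylphenyl)carbonyl on an aromatic carbon. Among the compounds with values here, no measured pair shows exactly this change. The nearest is an at least 1300-fold higher number from compound 1 to compound 3 (3.12 log units; beyond the scatter), where the carbonyl linker in place of a methylene replaced a number with a limit; an at least 15000-fold higher number from compound 2 to compound 3 (4.18 log units; beyond the scatter) points the same way. Compound 4 carries a methylene-oxygen linker rather than a carbonyl, and so stands closer to compound 1 and compound 2 than to compound 3. A large fall in the number is therefore expected, though the added oxygen and the shifted methyl leave its size uncertain. For compound 4 a value of 500 nM is estimated, between 50 nM and 10000 nM, a step of an at least 400-fold lower number from compound 3 to compound 4 (2.60 log units; beyond the scatter) that is expected to bring compound 4 back within the measurable range.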

Compound 4, half-maximal inhibitory concentration: 17000 nM
Estimate against measurement, compound 4: 34-fold (1.53 log units) below; measured number above the stated range.
By their numbers in this assay, from the lowest: compound 2; then compound 1; then compound 4. At a limit, above all of these: compound 3.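

Exchanging (3-methylphenyl)carbonyl for (3-methylbenzyl)oxy on the aromatic carbon between two ring nitrogen atoms turns a result without a number into a readable one in this assay, with an at least 11-fold lower number from compound 3 to compound 4 (1.07 log units; beyond the scatter). The recovery is only partial, however, as the oxygen-containing linker remains well short of the two methylene-linked compounds, with a 110-fold higher number from compound 1 to compound 4 (2.05 log units; beyond the scatter) and a 1300-fold higher number from compound 2 to compound 4 (3.12 log units; beyond the scatter). Compound 3 still gives only a limit and not a number, so the first of these steps has no exact size: the limit of > 200000 nM in this assay, at which 1 of the 4 values shown sits.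

No pair shown separates the effect of the linker oxygen from that of the methyl group's place on the benzyl ring. The compounds also leave open how an amine in the linker, or a longer chain between the ring and the core, would read here.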